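Swapping tert-butyl for fluoro on the aryl ketone side chain

The compounds below may be only part of what the source reports. "The series", "measured", "known", "first", "only" and "open" are said of these compounds alone.

Measured compounds:
Compound 1, `OC1CN(CCCCc2ccccc2)CCc2cc(OCc3ccccc3)ccc21`, gives 293 nM in an assay for displacement of a labelled ligand from Sigma non-opioid intracellular receptor 1 (Cavia porcellus), read by scintillation counting, with a stated time of 180 min; on this read-out higher numbers stand for weaker inhibition and lower numbers for stronger inhibition.
Compound 2, `OC1CN(CCCSc2ccccc2)CCc2cc(OCc3ccccc3)ccc21`, gives 376 nM in this assay.
Compound 3, `CC(C)(C)c1ccc(C(=O)CCCN2CCc3cc(OCc4ccccc4)ccc3C(O)C2)cc1`, gives only a limit, > 1000 nM, in this assay.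

Going by the values given here, compound 3 is the one compound that sits at the limit of > 1000 nM in this assay, at which 1 of the 3 values shown sits, so its true value is not known as a number. Compound 4, `O=C(CCCN1CCc2cc(OCc3ccccc3)ccc2C(O)C1)c1ccc(F)cc1`, has not yet been measured. It differs from compound 3 by one change, (fluoro in place of tert-butyl on an aromatic carbon).

Among the compounds with values here, the only measured step, a 1.3-fold higher number from compound 1 to compound 2 (0.11 log units; within the scatter), concerns a different change at a different place and gives no guide to a swap of groups on an aromatic carbon. Since compound 3 stands at a limit, even the starting point of the step is uncertain. The expectation is therefore wide: compound 4 is estimated to give 800 nM, with a range from 200 nM to 3000 nM. That estimate corresponds to an expected step of an at least 1.2-fold lower number from compound 3 to compound 4 (0.09 log units; that floor lies within the scatter), and the chance that only a limit is again reported remains substantial.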

Compound 4, inhibition constant: 293 nM
Estimate against measurement, compound 4: 2.7-fold (0.44 log units) above, within the range that was stated.
By their numbers in this assay, from the lowest: compounds 1, 4 and 2 (each within the scatter of the next). At a limit, above all of these: compound 3.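

Compound 3 gives only a limit in this assay, not a number: the limit of > 1000 nM in this assay, at which 1 of the 4 values shown sits.

Even so, the group on this aromatic carbon clearly matters, as fluoro in place of tert-butyl gives an at least 3.4-fold lower number from compound 3 to compound 4 (0.53 log units; beyond the scatter), the first step here that lies beyond the scatter. With fluoro in place, the aryl ketone side chain cannot be told apart from the other two chains, as the steps read a 1.3-fold lower number from compound 2 to compound 4 (0.11 log units; within the scatter) and no change at the digits printed from compound 1 to compound 4 (within the scatter).

The compounds shown leave open whether the step reflects fluoro itself or simply the loss of tert-butyl, a question that hydrogen, chloro or methoxy on the same carbon could help settle. Also unknown is how far compound 3 lies past its limit, and with it the full size of this step.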